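The compounds below may be only part of what the source reports. "The series", "measured", "known", "first", "only" and "open" are said of these compounds alone.

In a functional assay on KB cells (Homo sapiens) for antiproliferative activity, read by sulforhodamine B assay, with a stated time of 3 days (a higher number here means that more compound is needed for the effect, a lower number that less compound is needed), compound 1 `CCC1=C(O)c2c(oc(-c3ccc(Br)cc3)cc2=O)C(CC)(CC)C1=O` gives > 48.1 uM as a limit of the assay, not a number. Among the measured compounds shown here, compound 2 `CCC1=C(O)c2c(oc(-c3cccc(OC)c3)cc2=O)C(CC)(CC)C1=O` stands at 13.3 uM and holds the only true number so far. Compound 3 `CCC1=C(O)c2c(oc(-c3ccccc3C)cc2=O)C(CC)(CC)C1=O` has not yet been measured and differs from compound 2 by 2-methylphenyl in place of 3-methoxyphenyl on an aromatic carbon next to the ring oxygen 2-methylphenyl in place of 3-methoxyphenyl on an aromatic carbon on the shared core. For the measured compounds named here, one measured step bears on this carbon: an at least 3.6-fold lower number from compound 1 to compound 2 (0.55 log units; beyond the scatter) shows that swapping one substituted phenyl for another here can move the number in this assay beyond the scatter. That step involves no methyl group, so it shows that a move is possible but gives no firm direction. A small rise in the number, within the scatter, is therefore expected. The expected step is a 1.4-fold higher number from compound 2 to compound 3 (0.15 log units; within the scatter) and nothing larger is assumed. For compound 3 the estimate is 19 uM with an expected range from 7 uM to 45 uM in this measurement.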

Compound 3, concentration for half-maximal effect: 40.9 uM
Estimate against measurement, compound 3: 2.2-fold (0.33 log units) below; the measured number falls inside the stated range.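

In this assay, replacing 3-methoxyphenyl with 2-methylphenyl on the aromatic carbon next to the ring oxygen gives a 3.1-fold higher number from compound 2 to compound 3 (0.49 log units; beyond the scatter). Among the compounds shown here, this is the first step at this position measured between two true numbers, so it shows both a size and a direction, and the direction favours 3-methoxyphenyl over 2-methylphenyl. Compound 1 stands at a limit of the assay, not a number. Replacing 4-bromophenyl with 2-methylphenyl at this position gives an at least 1.1-fold lower number from compound 1 to compound 3 (0.07 log units; that floor lies within the scatter), so this step sets no clear order: the limit of > 48.1 uM in this assay, at which 1 of the 3 values shown sits.

The group and its place on the phenyl ring change together here, so the compounds shown cannot separate the effect of methoxy versus methyl from that of the 3-position versus the 2-position. On these data alone, how this position would respond to a phenyl ring carrying an amine or a carboxylic acid also remains open.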